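The compounds below may be only part of what the source reports. "The series", "measured", "known", "first", "only" and "open" are said of these compounds alone.

Measured so far:
compound 1, `CCCCn1ccc(-c2ccc(Oc3ccnc(C)c3)cc2)c(C#N)c1=O`: 243%
compound 2, `CCCCn1ccc(-c2ccc(Oc3ccc(C)nc3C)cc2)c(C#N)c1=O`: 239%

In a functional assay on CHO cells for positive allosteric modulation of metabotropic glutamate receptor 2 (Homo sapiens), read by scintillation counting and GTPgammaS binding, with a stated time of 30 min (on this read-out lower numbers stand for smaller maximal responses and higher numbers for larger maximal responses), compound 2 stands beside compound 1: a number 4 percentage points lower from compound 1 to compound 2 (within the scatter), so on this read-out the two cannot be told apart. Compound 3, `Cc1ccc(Oc2ccc(-c3ccn(CC4CC4)c(=O)c3C#N)cc2)c(C)n1`, differs from compound 2 in one place: cyclopropyl in place of propyl on a saturated chain carbon bound to an aromatic nitrogen. Among the compounds with values here, the only measured step concerned a different part of the molecule, the group on the oxygen on the aromatic ring, so no measured step bears directly on this change. That step was itself small, and nothing measured here shows the maximal response reacting to any change. On this basis compound 3 is expected to stay close to compound 2, with a number 1 percentage points higher from compound 2 to compound 3 (within the scatter) as the expected step, in no particular direction and not beyond the scatter. The estimate for compound 3 is 240%, in the range 200% to 280%.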

Compound 3, largest response reached (Emax), in percent of the reference or control that the assay uses: 183%
For compound 3 the middle estimate is 57 percentage points above the measured one; measured number below the stated range.
By their numbers in this assay, from the lowest: compound 3; then compounds 2 and 1 (each within the scatter of the next).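

This is the first change shown to move the maximal response: in this assay, cyclopropyl in place of propyl on a saturated chain carbon bound to an aromatic nitrogen gives a number 56 percentage points lower from compound 2 to compound 3 (beyond the scatter), a large step, whereas the change on the oxygen gave only a number 4 percentage points lower from compound 1 to compound 2 (within the scatter). The two groups match in their 3 carbon atoms, in having no hydrogen-bond donors or acceptors and in carrying no net charge, and they differ in the three-membered ring, so this position responds to a change that leaves those counts untouched. Nothing measured here explains the drop.

Going by these compounds, whether a longer chain such as pentyl, or a larger ring such as cyclobutyl, would stay near compound 2 or fall towards compound 3 remains open. Also open, on these data alone, is whether cyclopropyl has the same effect when the group on the oxygen is the 2-methylpyridin-4-yl of compound 1.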